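Lipophilicity of a Fused-Ring Series: From Phenoxy to Amide

The source may hold more compounds than are shown below. What is called first, only, known or untested is meant among the compounds shown, and "the series" means these compounds.

Compound 1 `CNC(=O)c1ccc(-c2cnc(NCc3c(F)ccc4c3CCO4)c3cn[nH]c(=O)c23)c(C)n1`: 2.9
Compound 2 `Fc1ccc2c(c1CNc1ncc(Oc3ccccc3)c3nncn13)CCO2`: 3.5
Compound 3 `Cc1ncccc1-c1cnc(NCc2c(F)ccc3c2CCO3)n2c(=O)[nH]nc12`: 3

These three compounds share a core and were measured in a physicochemical assay for lipophilicity, using the shake flask method, in phosphate buffer, measured as octanol-water partition, with a stated time of 30 min, at pH 7.4; a higher number here means a more lipophilic compound, a lower number a more polar compound. Compound 2 stands highest of the three; compound 3 lies lower by a margin beyond the scatter, and compound 1 lies further below, also beyond the scatter. Compound 4 `COCCC(=O)Nc1cnc(NCc2c(F)ccc3c2CCO3)n2cnnc12` is not yet measured. It differs from compound 2 in one place: ((2-methoxyethyl)carbonyl)amino in place of phenoxy on an aromatic carbon. Within the data shown here, no step between measured compounds covers this kind of change, so the expectation rests on compound 2 and its value of 3.5 alone. The change is expected to lower the number well beyond the scatter, an estimated step of a number 1.50 log units lower from compound 2 to compound 4 (beyond the scatter). Compound 4 is therefore expected to give about 2, within a range from 1.4 to 2.6.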

Compound 4, distribution coefficient: 1.4
The estimate for compound 4 lay 0.60 log units above the measured number; the measured number falls inside the stated range.
By their numbers in this assay, from the lowest: compound 4; then compounds 1 and 3 (each within the scatter of the next); then compound 2.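

On an aromatic carbon of the shared core, ((2-methoxyethyl)carbonyl)amino in place of phenoxy gives, in this assay, a number 2.10 log units lower from compound 2 to compound 4 (beyond the scatter), a large step for a change that keeps the heavy-atom count. The exchange replaces a six-membered aromatic ring with an open chain and adds a hydrogen-bond donor. Nothing available here shows which part of the exchange accounts for the step. As far as these compounds go, whether an acetylamino group would give a similar step remains open. The same applies to an amine or a carboxylic acid on this carbon.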